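Chlorophenyl regioisomers on the carbon double-bonded to nitrogen

The source may report more compounds than this note shows. Statements on the series, on what has been measured and on what is new or still open speak of the compounds shown alone.

Measured compounds:
compound 1 `CSc1ccc(/C=N/n2c(Cc3ccc(S(C)(=O)=O)cc3)n[nH]c2=S)cc1` gives 57.5% in a functional assay on HeLa cells (Homo sapiens) for cytotoxicity, read by MTT assay, with a stated time of 48 h, tested at 50 uM; a higher number here means a stronger effect of the compound at the concentration tested, a lower number a weaker effect
compound 2 `CS(=O)(=O)c1ccc(Cc2n[nH]c(=S)n2/N=C/c2cccnc2)cc1` gives 14%
compound 3 `CS(=O)(=O)c1ccc(Cc2n[nH]c(=S)n2/N=C/c2ccccc2Cl)cc1` gives 42.7%

Compound 3 stands second highest of the three numbers in this assay. Compound 1 lies above it, the step being a number 14.8 percentage points lower from compound 1 to compound 3 (beyond the scatter); compound 2 lies below it, the step being a number 28.7 percentage points higher from compound 2 to compound 3 (beyond the scatter). Compound 4 `CS(=O)(=O)c1ccc(Cc2n[nH]c(=S)n2/N=C/c2ccc(Cl)cc2)cc1` differs from compound 3 only by 4-chlorophenyl in place of 2-chlorophenyl on a carbon with a double bond to nitrogen. Among the compounds with values here, every measured step exchanges one aryl ring for a different kind of ring; none moves a chlorine within the same phenyl ring, so no step bears directly on this change. The expectation for compound 4 therefore rests on the value of compound 3, with a wide range. The step of a number 2.3 percentage points higher from compound 3 to compound 4 (within the scatter) is expected to stay within the scatter. Compound 4 is estimated at 45%, between 25% and 65%.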

Compound 4, a percentage reported as activity, at one concentration (the size of the read-out at that concentration, not a potency): 54%
Estimate against measurement, compound 4: 9 percentage points below; measured number inside the range.
By their numbers in this assay, from the lowest: compound 2; then compound 3; then compounds 4 and 1 (each within the scatter of the next).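

In this assay the place of the chlorine on the phenyl ring counts, even though the two rings have the same atoms: a number 11.3 percentage points higher from compound 3 to compound 4 (beyond the scatter). The step from the pyridin-3-yl ring is larger, a number 40 percentage points higher from compound 2 to compound 4 (beyond the scatter), while chloro in place of methylsulfanyl gives a number 3.5 percentage points lower from compound 1 to compound 4 (within the scatter), so the two para-free names 4-chlorophenyl and 4-(methylsulfanyl)phenyl cannot be told apart here. No measurement at hand accounts for the gap between the two chlorophenyl compounds.

On these data alone, whether an amine or a carboxylic acid in place of chloro on the phenyl ring would keep the number of compound 4 remains open.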